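Solubility notes: phenoxy-type groups entering on the shared core

The source may hold more compounds than are shown below. What is called first, only, known or untested is meant among the compounds shown, and "the series" means these compounds.

Measured so far:
- compound 1, `CC(C)CCc1ccc2c(NCCCNCc3ccco3)ccnc2c1`, gives 4200 nM in a physicochemical assay for solubility, with a stated time of 18 h, at pH 7.4; on this read-out higher numbers stand for higher solubility and lower numbers for lower solubility
- compound 2, `COc1ccc(F)cc1CNCCCNc1ccnc2cc(Cc3ccccc3)ccc12`, gives 4200 nM
- compound 3, `Clc1ccc(Oc2ccc3c(NCCCNCc4ccco4)ccnc3c2)cc1`, gives 14500 nM

Compound 2 stands level with compound 1 at the digits shown, and the two together hold the lowest numbers of the three; compound 3 shows a higher number than compound 2, while the gap between compound 1 and compound 2 is within the scatter. Going by the values given here, the one step so far between compounds differing in a single place is a 3.5-fold higher number from compound 1 to compound 3 (0.54 log units; beyond the scatter), a modest rise that goes beyond the scatter.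

The next compound, compound 4, `COc1ccc(F)cc1CNCCCNc1ccnc2cc(Oc3ccccc3OC)ccc12`, differs from compound 2 by 2-methoxyphenoxy in place of benzyl on an aromatic carbon. The step from compound 1 to compound 3 bears on this: there too a phenoxy-type group entered on an aromatic carbon of the shared core, and the solubility number rose. On that single precedent, a modest rise beyond the scatter is expected for compound 4, of about a 2.0-fold higher number from compound 2 to compound 4 (0.31 log units; beyond the scatter), though one step is thin ground and no change beyond the scatter cannot be ruled out. The estimate for compound 4 in this assay is 8500 nM, with a range from 3000 nM to 22000 nM.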

Compound 4, solubility: 14500 nM
For compound 4 the middle estimate is 1.7-fold (0.23 log units) below the measured one; the range from low to high includes it.
By their numbers in this assay, from the lowest: compounds 1 and 2 (each within the scatter of the next); then compounds 3 and 4 (each within the scatter of the next).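

Replacing benzyl with 2-methoxyphenoxy on this aromatic carbon, meta to a fused ring and para to a fused ring, gives a 3.5-fold higher number from compound 2 to compound 4 (0.54 log units; beyond the scatter) in this assay. The earlier step, a 3.5-fold higher number from compound 1 to compound 3 (0.54 log units; beyond the scatter), therefore no longer stands alone: the two steps match at the digits printed, although the group leaving, the group entering and the rest of the molecule all differ between the two pairs, so the rise on entry of a phenoxy-type group now holds in both pairs shown, with no compound here going against it. Nothing shown here accounts for either step, and the cause remains unexplained.

The two steps do not separate the bridging oxygen from the substituents on the phenoxy ring, so it remains unclear whether unsubstituted phenoxy would give a step of the same size, or whether the 4-chloro and 2-methoxy substituents matter at all. As far as these compounds go, it is also open how the number would respond to a different kind of group on this aromatic carbon, such as a morpholine, a primary amine or a carboxylic acid.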